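Methoxycarbonyl in place of chloro: working notes

This account rests on a few compounds, and the source may have more. Where it says the series, first, only, none or still open, it means among the compounds named here.

Compound 1 `COc1ccc(-c2cccc(NC(=O)C(Cl)Cl)c2)cc1` reaches only a limit in a functional assay on KB 3-1 cells (Homo sapiens) for cytotoxicity, read by MTT assay, with a stated time of 68 h (on this read-out lower numbers stand for stronger inhibition and higher numbers for weaker inhibition), at > 50000 nM. Going by the values given here, compound 2 `O=C(Nc1cccc(-c2ccc(Cl)cc2)c1)C(Cl)Cl` gives 38200 nM in this assay, the only true number so far. Compound 3 `COC(=O)c1ccc(-c2cccc(NC(=O)C(Cl)Cl)c2)cc1` carries methoxycarbonyl in place of chloro on an aromatic carbon, para to a large group: methoxycarbonyl in place of chloro on an aromatic carbon. Among the compounds with values here, the sole measured guide, with chloro in place of methoxy on an aromatic carbon, is an at least 1.3-fold lower number from compound 1 to compound 2 (0.11 log units; that floor lies within the scatter), and the limit of > 50000 nM in this assay, at which 1 of the 2 values shown sits, leaves its true size open. The expected change is therefore small, a 1.2-fold higher number from compound 2 to compound 3 (0.07 log units; within the scatter), and none beyond the scatter is expected. For compound 3 the estimated value is 45000 nM, with an expected range of 20000 nM to 90000 nM.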

Compound 3, half-maximal inhibitory concentration: > 50000 nM
Compound 3 ended at the assay's limit; the forecaster's own chance of this, stated with the estimate: 50%; at least 1.1-fold (0.04 log units) between middle value and limit.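

Methoxycarbonyl in place of chloro at this carbon, para to a large group, gives an at least 1.3-fold higher number from compound 2 to compound 3 (0.11 log units; that floor lies within the scatter) in this assay. Of the three groups shown at this carbon, only chloro gives a true number; methoxy and methoxycarbonyl both end at a limit. The step between compound 1 and compound 3 cannot be read: the limit of > 50000 nM in this assay, at which 2 of the 3 values shown sit.

From the compounds shown here alone, the true size of the step to methoxycarbonyl stays open, since its floor does not pass the scatter. Also open, going by these compounds, is whether an amine or a carboxylic acid at this carbon would give a true number in this assay.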